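Changing the group on the ring nitrogen: working notes

The compounds below may be only part of what the source reports. "The series", "measured", "known", "first", "only" and "open" are said of these compounds alone.

Values in a functional assay on SGC-7901 cells (Homo sapiens) for inhibition, read by MTT assay, with a stated time of 72 h; on this read-out lower numbers stand for stronger inhibition of growth and higher numbers for weaker inhibition of growth:
Compound 1 `O[C@H](COCCOC[C@@H](O)Cc1cn(Cc2ccc(Oc3ccccc3)cc2)nn1)Cc1ccc(-c2ccccc2)cc1`: 4500 nM
Compound 2 `O=c1[nH]c2ccc(-n3cc(C[C@H](O)COCCOC[C@@H](O)Cc4ccc(-c5ccccc5)cc4)nn3)cc2s1`: 10500 nM

Compound 2 gives the higher of the two numbers, and its gap to compound 1 lies beyond the scatter. Compound 3 `N#Cc1ccc(Cn2cc(C[C@H](O)COCCOC[C@@H](O)Cc3ccc(-c4ccccc4)cc3)nn2)cc1` differs from compound 2 by a group of 9 heavy atoms (8 carbon, 1 nitrogen; one six-membered aromatic ring of carbon only) in place of a group of 10 heavy atoms (7 carbon, 1 nitrogen, 1 oxygen, 1 sulfur; one five-membered aromatic ring with 2 hetero atoms, one six-membered aromatic ring of carbon only), on an aromatic nitrogen. Among the compounds with values here, no two measured compounds differ in one place, so no measured step tells how this position responds. Compound 1 carries on the same ring nitrogen a group built on a six-membered aromatic carbon ring, as compound 3 does, so the expected step of a 2.1-fold lower number from compound 2 to compound 3 (0.32 log units; beyond the scatter) is toward a lower number, beyond the scatter but modest. Compound 3 is expected at 5000 nM (range 2000 nM to 14000 nM) in this assay, the estimate resting on compound 1, which gives 4500 nM.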

Compound 3, concentration for 50% growth inhibition: 7700 nM
Beside the measured number, compound 3's estimate is 1.5-fold (0.19 log units) below it; the measured number falls inside the stated range.
By their numbers in this assay, from the lowest: compounds 1, 3 and 2 (each within the scatter of the next, the first and the last beyond it).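

In this assay, within the data shown here, 4-cyanobenzyl entering on the aromatic nitrogen gives a 1.4-fold lower number from compound 2 to compound 3 (0.13 log units; within the scatter), the first single-place reading at this position, and it shows that this exchange of groups does not move the number beyond the scatter. Cyano in place of phenoxy on an aromatic carbon gives a 1.7-fold higher number from compound 1 to compound 3 (0.23 log units; within the scatter), so this change also stays within the scatter, and the read-out does not separate the two groups. Nothing measured here offers an explanation for either step.

From the compounds shown here alone, whether an amine or a carboxylic acid in place of the cyano would shift the number beyond the scatter remains open. The same question stands for a longer chain between the aromatic nitrogen and its six-membered aromatic carbon ring.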